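The source may report more compounds than this note shows. Statements on the series, on what has been measured and on what is new or still open speak of the compounds shown alone.

Compound 3, `O=[N+]([O-])c1ccc(Cn2cc(COc3ccc(Cl)cc3)nn2)cc1`, was tested in an ADME assay on A549 cells (Homo sapiens) for inhibition, read by MTT assay, with a stated time of 48 h; a lower number here means a stronger inhibitor of growth, a higher number a weaker inhibitor of growth. In this assay compound 3 gives only a limit, > 100 ug/mL. Compound 1, `Clc1ccc(Cn2cc(COc3ccccc3)nn2)cc1`, likewise gives a limit in this assay, > 100 ug/mL. Compound 2, `Cc1ccc(OCc2cn(Cc3ccc(Cl)cc3)nn2)cc1`, also returns a limit in this assay, > 100 ug/mL. Among the measured compounds shown here, the one measured step, a step that the two limits leave unreadable from compound 1 to compound 2, therefore cannot be read, and all that is known is the limit of > 100 ug/mL in this assay, at which 3 of the 3 values shown sit. Compound 4, `Clc1ccc(Cn2cc(COc3ccc(Cl)cc3)nn2)cc1`, differs from compound 3 by chloro in place of nitro on an aromatic carbon. No measured step bears on this change, so the expectation rests only on the limit shown for compound 3, > 100 ug/mL, and a step that the limit leaves unreadable from compound 3 to compound 4 within the scatter is expected. Compound 4 is therefore estimated at 150 ug/mL, with a range from 50 ug/mL to 450 ug/mL.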

Compound 4, concentration for 50% growth inhibition: > 100 ug/mL
Compound 4: only a limit was reported (the forecaster's own chance of this, stated with the estimate: 80%); the middle value lies beyond the limit too.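

None of the steps from compound 1, compound 2 or compound 3 to compound 4 can be read in this assay: each value there is only a limit. The compounds shown leave open how strongly any of them inhibits growth and whether any of these aromatic substituents changes it.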